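The source may hold more compounds than are shown below. What is called first, only, known or untested is meant among the compounds shown, and "the series" means these compounds.

Compound 1 `COc1cc2c(Nc3ccc(C#N)cc3)ncnc2cc1OCCCN1CCCC1`, compound 2 `COc1cc2c(Nc3ccc(C#N)cc3)ncnc2cc1OCCCN1CCC(C)CC1` and compound 3 `COc1cc2c(Nc3ccc(C#N)cc3)ncnc2cc1OCCCN1CCC(O)CC1` have been measured in a functional assay on HepG2 cells (Homo sapiens) for antiproliferative activity, read by MTT assay, with a stated time of 72 h; on this read-out higher numbers stand for weaker inhibition and lower numbers for stronger inhibition: compound 1 gives 20900 nM, compound 2 gives 32100 nM and compound 3 gives 67900 nM.

Compound 3 therefore carries the highest number of the three and is the weakest inhibitor of the set, since a 3.2-fold higher number from compound 1 to compound 3 (0.51 log units; beyond the scatter) and a 2.1-fold higher number from compound 2 to compound 3 (0.33 log units; beyond the scatter), whereas a 1.5-fold higher number from compound 1 to compound 2 (0.19 log units; within the scatter). Compound 4 `COc1cc2c(Nc3ccc(C#N)cc3)ncnc2cc1OCCCN1CCc2ccccc2C1` differs from compound 3 by 1,2,3,4-tetrahydroisoquinolin-2-yl in place of 4-hydroxypiperidin-1-yl on a saturated chain carbon, three bonds along the chain from an oxygen on an aromatic ring. For the measured compounds named here, only the step from compound 2 to compound 3 touches the hydroxy group, and it raised the number modestly; compound 4 removes that hydroxy and brings in a larger amine, so a modest move back toward lower numbers is expected, roughly a 2.7-fold lower number from compound 3 to compound 4 (0.43 log units; beyond the scatter). Compound 4 is estimated to give 25000 nM, with a range of 8000 nM to 80000 nM.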

Compound 4, half-maximal inhibitory concentration: > 100000 nM
Compound 4 ended at the assay's limit (the forecaster's own chance of this, stated with the estimate: 5%); middle value at least 4.0-fold (0.60 log units) away from the limit.
By their numbers in this assay, from the lowest: compounds 1 and 2 (each within the scatter of the next); then compound 3. At a limit, above all of these: compound 4.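

In this assay, compound 4 gives no number, only a limit: the limit of > 100000 nM in this assay, at which 1 of the 4 values shown sits.

This position therefore tolerates some amines far better than others: 1,2,3,4-tetrahydroisoquinolin-2-yl gives an at least 3.1-fold higher number from compound 2 to compound 4 (0.49 log units; beyond the scatter) and an at least 4.7-fold higher number from compound 1 to compound 4 (0.67 log units; beyond the scatter). Losing the hydroxy group did not by itself bring a lower number, although an at least 1.4-fold higher number from compound 3 to compound 4 (0.16 log units; that floor lies within the scatter) has a floor too small to separate the two compounds.

As far as these compounds go, it remains open whether morpholin-4-yl or unsubstituted piperidin-1-yl on the same chain carbon would match compound 1, and whether the aromatic ring alone accounts for the result in compound 4.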